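A few compounds are considered here, and "the series" means these few. Any claim that something is new, unique, unknown or untested is made for them only; others in the source may bear on it.

Two quinazolines have been measured so far. Compound 1 `Cc1cc(Nc2nc(NCc3ccc(F)cc3F)nc3ccccc23)n[nH]1` and compound 2 `CCc1cc(Nc2nc(NCc3ccc(F)cc3)nc3ccccc23)n[nH]1` were both tested in an assay for inhibition of high affinity nerve growth factor receptor (Homo sapiens), read by HTRF, with a stated time of 30 min, in the presence of a further agent that is not named here; on this read-out higher numbers stand for weaker inhibition and lower numbers for stronger inhibition. In this assay compound 1 gives 200 nM, while compound 2 gives 53 nM, the lower of the two numbers and beyond the scatter away from compound 1. Compound 1 differs from compound 2 in more than one place, so the two cannot be set against each other for any single change.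

The next compound, compound 3 `CCc1cc(Nc2nc(NCc3ccc(F)cc3F)nc3ccccc23)n[nH]1`, is not yet measured. It differs from compound 2 in one place: fluoro in place of hydrogen on an aromatic carbon. Going by the values given here, no measured pair shows this change on its own, so there is no step to lean on. On what is known, the change is expected to shift the number in this assay by no more than the scatter, if at all, with a slight lean towards a higher number. The expected step is a 1.3-fold higher number from compound 2 to compound 3 (0.12 log units; within the scatter). Compound 3 is therefore estimated at 70 nM in this assay, within a range from 25 nM to 200 nM.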

Compound 3, half-maximal inhibitory concentration: 20 nM
For compound 3 the middle estimate is 3.5-fold (0.54 log units) above the measured one; the measured number lies below the stated range.
By their numbers in this assay, from the lowest: compound 3; then compound 2; then compound 1.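

In this assay, fluoro in place of hydrogen on an aromatic carbon, ortho to a large group and meta to a fluoro group, turns the 4-fluorobenzyl group into the 2,4-difluorobenzyl group and gives a 2.7-fold lower number from compound 2 to compound 3 (0.42 log units; beyond the scatter), so this position does more than merely accept the added atom: the change lowers the number beyond the scatter. Compound 3 also provides the link that compound 1 and compound 2 could not provide on their own, since it isolates the other change, methyl in place of hydrogen on a saturated chain carbon bound to an aromatic carbon, which gives a 10-fold lower number from compound 1 to compound 3 (1.00 log units; beyond the scatter) in the presence of the 2,4-difluorobenzyl group. Nothing available explains why either change lowers the number.

The compounds shown leave open whether chlorine or a methoxy group on the same aromatic carbon would lower the number as fluoro does. They also leave open whether a longer chain, such as propyl, in place of the ethyl group of compound 3 would continue the step seen on going from methyl to ethyl.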